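Methoxycarbonyl for cyano on the shared core

This account rests on a few compounds, and the source may have more. Where it says the series, first, only, none or still open, it means among the compounds named here.

compound 1, `O=[N+]([O-])c1ccccc1CNc1cc(Br)cc2[nH]ncc12`: 39000 nM
compound 2, `CNC(=O)c1cccc(CNc2cc(C(F)(F)F)cc3[nH]ncc23)c1`: 4870 nM
compound 3, `N#Cc1cc(NCc2ccccc2[N+](=O)[O-])c2cn[nH]c2c1`: > 100000 nM

In an assay for inhibition of Tryptophan 2,3-dioxygenase (Homo sapiens), with stated times of 10 min and 60 min (on this read-out lower numbers stand for stronger inhibition and higher numbers for weaker inhibition), compound 1 gives 39000 nM and compound 2 gives 4870 nM. For compound 3 the read-out is only a limit, > 100000 nM, and not a number. Compound 3 thus stands at the limit of > 100000 nM in this assay, at which 1 of the 3 values shown sits, the far end of what the assay reports. Going by the values given here, the one measured step that changes a single place, an at least 2.5-fold higher number from compound 1 to compound 3 (0.40 log units; beyond the scatter), runs into that limit. Compound 4, `COC(=O)c1cc(NCc2ccccc2[N+](=O)[O-])c2cn[nH]c2c1`, differs from compound 3 by methoxycarbonyl in place of cyano on an aromatic carbon. Among the compounds with values here, no measured step exchanges cyano for methoxycarbonyl, and the step from bromo to cyano gives no direction for an ester at the same place. Compound 2 carries trifluoromethyl on the shared core, but it differs from compound 3 elsewhere as well, so its value stands on its own and cannot be read as a step. Compound 4 is therefore expected to remain close to the limit, a step of a number no higher from compound 3 to compound 4 (the limit leaves the size open) being what the estimate means. The estimated value for compound 4 is 100000 nM, with a range from 30000 nM to 300000 nM.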

Compound 4, half-maximal inhibitory concentration: > 100000 nM
Compound 4 was reported as a limit; the forecaster's own chance of this, stated with the estimate: 60%; the middle value sits exactly at the limit.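

In this assay compound 4 gives > 100000 nM, which is a limit and not a number. With methoxycarbonyl in place of bromo on this aromatic carbon, the read-out shows an at least 2.5-fold higher number from compound 1 to compound 4 (0.40 log units; beyond the scatter), so a second group at this place, larger by its count of heavy atoms than cyano, also gives a weaker reading than bromo, as an at least 2.5-fold higher number from compound 1 to compound 3 (0.40 log units; beyond the scatter) showed for cyano. The step between compound 3 and compound 4 cannot be read, and the change from cyano to methoxycarbonyl leaves this position at the far end of what the assay reports: the limit of > 100000 nM in this assay, at which 2 of the 4 values shown sit.

On these data alone, how far compound 3 and compound 4 lie beyond the limit remains open, and with it any order between cyano and methoxycarbonyl at this place. Also open, as far as these compounds go, is whether an amine or a carboxylic acid on this aromatic carbon would bring the read-out back within the range of the assay.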